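The source may hold more compounds than are shown below. What is called first, only, known or untested is meant among the compounds shown, and "the series" means these compounds.

Measured in an ADME assay on BCBL1 cells (Homo sapiens) for cytotoxicity, with a stated time of 7 days; a higher number here means that more compound is tolerated, a lower number that less compound is tolerated:

- compound 1 `Nc1nc(NCc2ccccc2)c2ncn(/C=C3/CC3(CO)CO)c2n1` gives 19900 nM
- compound 2 `Nc1nc2c(ncn2/C=C2/CC2(CO)CO)c(=O)[nH]1` gives only a limit of the assay, > 20000 nM
- compound 3 `CCCCCCCCSc1nc(N)nc2c1ncn2/C=C1/CC1(CO)CO` gives only a limit of the assay, > 20000 nM

Compound 1 is the only one of the three with an actual number; the two other results are limits. One measured step changes a single place on the shared core: a number no lower from compound 1 to compound 3 (the limit leaves the size open). Among the measured compounds shown here, that step is the only one that bears on compound 4 `CCCCCCSc1nc(N)nc2c1ncn2/C=C1/CC1(CO)CO`, which differs from compound 1 by hexylsulfanyl in place of benzylamino on an aromatic carbon. The hexylsulfanyl chain of compound 4 is shorter than the octylsulfanyl chain of compound 3, but both replace benzylamino at the same place. For the measured compounds named here, because of the limit of > 20000 nM in this assay, at which 2 of the 3 values shown sit, the measured step shows no readable size, only that the number did not fall. No drop beyond the scatter is therefore expected, and a rise is possible. Compound 4 is estimated at 25000 nM, within 12000 nM to 60000 nM. That estimate means an expected step of a 1.3-fold higher number from compound 1 to compound 4 (0.10 log units; within the scatter), and the assay will most likely again report only a limit.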

Compound 4, half-maximal cytotoxic concentration: > 20000 nM
Compound 4: a limit, no number; the forecaster's own chance of this, stated with the estimate: 70%; the middle value is on the limit's open side.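

At this aromatic carbon, hexylsulfanyl in place of benzylamino gives, in this assay, a number no lower from compound 1 to compound 4 (the limit leaves the size open). Until now only the octylsulfanyl chain had shown this at the same place; with two chain lengths, neither sulfur-linked chain brings the number down. Whether chain length matters cannot be seen, and the step between compound 3 and compound 4 cannot be read because both results are limits: the limit of > 20000 nM in this assay, at which 3 of the 4 values shown sit.

As far as these compounds go, it stays open whether a longer chain such as decylsulfanyl would bring the number down to a readable value. A short methylsulfanyl group, or a hexylamino chain joined through nitrogen as benzylamino is, could also show whether the sulfur link or the chain itself goes with the number not falling.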